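Removing an ortho fluoro from a phenylpiperazine succinimide

The source may hold more compounds than are shown below. What is called first, only, known or untested is meant among the compounds shown, and "the series" means these compounds.

Measured compounds:
compound 1, `CCC(C(=O)N1CCN(c2ccccc2F)CC1)N1C(=O)CCC1=O`, 50%
compound 2, `COCC(C(=O)N1CCN(c2cccc(C(F)(F)F)c2)CC1)N1C(=O)CCC1=O`, 100%

Compound 1 was tested in a functional assay on the whole organism (strain Swiss) with Mus musculus as the target, in the maximal electroshock model, with a stated time of 1 h, at a dose of 300 mg/kg by the intraperitoneal route (on this read-out lower numbers stand for a weaker effect and higher numbers for a stronger effect at the one dose given), and gives 50%. Of the two numbers on hand it is the lower one; its nearest neighbour, compound 2, stands far above it, a gap beyond the usual scatter. Among the compounds with values here, compound 2 differs from compound 1 in more than one place, so the two values show only that both compounds act in this assay and that compound 2 acts more strongly at the one dose given.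

Compound 3, `CCC(C(=O)N1CCN(c2ccccc2)CC1)N1C(=O)CCC1=O`, has not yet been measured. It differs from compound 1 as follows: hydrogen in place of fluoro on an aromatic carbon, that is, on an aromatic carbon of the six-membered carbon-only ring, ortho to a large group. Within the data shown here, with no step between measured compounds available for such a change, the expected step of no change at the digits printed from compound 1 to compound 3 (within the scatter) is one of no clear direction and within the scatter. Compound 3 is therefore expected to give about 50%, in a range from 20% to 80%.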

Compound 3, a percentage reported as activity, at one dose (the size of the read-out at that dose, not a potency): 75%
Beside the measured number, compound 3's estimate is 25 percentage points below it, within the range that was stated.
By their numbers in this assay, from the lowest: compound 1; then compound 3; then compound 2.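

In this assay, within the data shown here, this is the first comparison in which only one place changes, and it reads a number 25 percentage points higher from compound 1 to compound 3 (beyond the scatter). It shows that the substituent at this place on the aromatic ring, ortho to a large group, can shift the read-out beyond the scatter. Fluoro is not required for the effect at the one dose given, since the change from 2-fluorophenyl to phenyl leaves compound 3 active and above compound 1, and no measurement on hand accounts for this step.

As far as these compounds go, whether a chloro or a methoxy group at the same place would stand nearer to fluoro or to hydrogen remains open. Also open, from the compounds shown here alone, is whether the same change would give a step of this size on a core carrying a longer chain.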